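Propanoyl for tert-butyl on a pyrimidinyl piperazine scaffold

The source may report more compounds than this note shows. Statements on the series, on what has been measured and on what is new or still open speak of the compounds shown alone.

The measured compounds:
compound 1, `CCC(=O)c1ccc(OCCCN2CCN(c3cnccn3)CC2)cc1`, 24.3 nM
compound 2, `CC(C)(C)c1ccc(OCCCN2CCN(c3ncccn3)CC2)cc1`, 25.6 nM

Of the compounds shown here, two have been tested in a functional assay on L5178Y cells (Mus musculus) for antiproliferative activity, read by MTT assay; a higher number here means a weaker inhibitor, a lower number a stronger inhibitor. Compound 1 carries a propanoyl group on its aromatic ring and gives 24.3 nM in this assay. Compound 2, which carries a tert-butyl group instead and a different heteroaryl on the piperazine, gives 25.6 nM in this assay. Compound 2 stands at one end of the two numbers, yet the two values fall within the scatter of one another, so nothing can be read into the gap between them.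

Compound 3, `CCC(=O)c1ccc(OCCCN2CCN(c3ncccn3)CC2)cc1`, has not been measured. It is compound 2 with propanoyl in place of tert-butyl on an aromatic carbon. Among the compounds with values here, the same exchange of groups is not documented in any measured pair, so no step size is known for it; the only guide is that compound 1, which already carries the propanoyl group, gives 24.3 nM, close to compound 2. Compound 3 is therefore expected to give 25 nM, within 10 nM to 60 nM. The expected step of a 1.0-fold lower number from compound 2 to compound 3 (0.01 log units; within the scatter) is estimated as none beyond the scatter.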

Compound 3, half-maximal inhibitory concentration: 36.9 nM
For compound 3 the middle estimate is 1.5-fold (0.17 log units) below the measured one, within the range that was stated.
By their numbers in this assay, from the lowest: compounds 1, 2 and 3 (each within the scatter of the next).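

In this assay, the exchange at the aromatic carbon, para to a large group, can now be read on its own: propanoyl in place of tert-butyl gives a 1.4-fold higher number from compound 2 to compound 3 (0.16 log units; within the scatter) and so stays small on this scaffold, even though the entering group brings a carbonyl and one hydrogen-bond acceptor where the leaving group has none. Within the data shown here, the second place can also be read alone for the first time, since pyrimidin-2-yl in place of pyrazin-2-yl on an amine nitrogen in a ring gives a 1.5-fold higher number from compound 1 to compound 3 (0.18 log units; within the scatter) with the propanoyl group held constant. Neither step lies beyond the scatter, so these three compounds show no preference at either place, and the two groups at each place cannot be ranked.

On these data alone, whether a group of another kind at the aromatic carbon, such as a primary amine, a carboxylic acid or a longer alkyl chain, would move the number beyond the scatter remains open. Nothing available bears on why the numbers of these compounds lie so close together.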